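The source may hold more compounds than are shown below. What is called first, only, known or untested is meant among the compounds shown, and "the series" means these compounds.

Compounds with measurements so far:
- compound 1 `Cc1c(C(=O)/C=C/c2ccc(Cl)cc2)[n+]([O-])c2ccccc2[n+]1[O-]`: 11000 nM
- compound 2 `Cc1ccc(/C=C/C(=O)c2c(C)[n+]([O-])c3ccccc3[n+]2[O-])cc1`: 4100 nM

Going by the values given here, compound 2 holds the lowest of the two numbers in a functional assay on HL-60 cells (Homo sapiens) for cytotoxicity, with a stated time of 48 h; a lower number here means that less compound is tolerated, a higher number that more compound is tolerated; the only neighbour is compound 1, whose value is the higher one. Among the compounds with values here, the single measured step, a 2.7-fold lower number from compound 1 to compound 2 (0.43 log units; beyond the scatter), replaced a halogen on the aromatic ring with a methyl, and was modest.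

Compound 3 `Cc1c(C(=O)/C=C/c2ccc(Br)cc2)[n+]([O-])c2ccccc2[n+]1[O-]` is not yet measured. Relative to compound 2 the change is bromo in place of methyl on an aromatic carbon, i.e. 4-methylphenyl to 4-bromophenyl, on a six-membered aromatic ring of carbon only. This is the mirror of the measured step: a halogen returns where the methyl was, with bromo instead of chloro. The step from compound 1 to compound 2 therefore bears on it, and it is expected to run the other way, giving a higher number of about the same size, a 2.2-fold higher number from compound 2 to compound 3 (0.34 log units; beyond the scatter). Compound 3 is thus estimated at 9000 nM, with a range of 3500 nM to 25000 nM.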

Compound 3, half-maximal cytotoxic concentration: 23000 nM
Beside the measured number, compound 3's estimate is 2.6-fold (0.41 log units) below it; measured number inside the range.
By their numbers in this assay, from the lowest: compound 2; then compound 1; then compound 3.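

In this assay the two halogens do not read as one group at this aromatic carbon, para to a large group: a 2.1-fold higher number from compound 1 to compound 3 (0.32 log units; beyond the scatter) for bromo in place of chloro. Bromo in place of methyl gives a 5.6-fold higher number from compound 2 to compound 3 (0.75 log units; beyond the scatter) and spans the whole range seen so far at this position, with the order from the lowest number being methyl, chloro, bromo across compound 2, compound 1 and compound 3. No measurement at hand accounts for this order.

The compounds shown leave open whether fluoro, methoxy or an amine on this carbon would fall within that order or outside it. They also leave open whether the same order would hold with other changes to the shared core.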